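Compound 3 to compound 4: methoxy in place of bromo

The compounds below may be only part of what the source reports. "The series", "measured", "known", "first", "only" and "open" are said of these compounds alone.

Three compounds of the series have numbers in a functional assay on SGC-7901 cells (Homo sapiens) for antiproliferative activity, read by sulforhodamine B assay, with a stated time of 72 h; a lower number here means a stronger inhibitor, a higher number a weaker inhibitor. Compound 1 `Cc1cccc(NC(=S)N/N=C/c2ccc3ccccc3n2)c1` gives > 100000 nM, which is a limit of the assay (the limit of > 100000 nM in this assay, at which 1 of the 3 values shown sits). Compound 2 `S=C(NCc1ccccc1)N/N=C/c1ccc2ccccc2n1` gives 53700 nM. Compound 3 `S=C(N/N=C/c1ccc2ccccc2n1)Nc1cccc(Br)c1` gives 78600 nM; of the two numbers it sits beside compound 2, and the step of a 1.5-fold higher number from compound 2 to compound 3 (0.17 log units; within the scatter) stays within the scatter. The step of an at least 1.2-fold lower number from compound 1 to compound 3 (0.10 log units; that floor lies within the scatter) likewise has a floor within the scatter, and an at least 1.8-fold lower number from compound 1 to compound 2 (0.27 log units; that floor lies within the scatter) does too.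

Compound 4 `COc1cccc(NC(=S)N/N=C/c2ccc3ccccc3n2)c1` differs from compound 3 by methoxy in place of bromo on an aromatic carbon. The measured steps that bear on this change are the substituent swap on the same aromatic carbon, an at least 1.2-fold lower number from compound 1 to compound 3 (0.10 log units; that floor lies within the scatter), and the aryl-for-benzyl swap, a 1.5-fold higher number from compound 2 to compound 3 (0.17 log units; within the scatter); neither moves beyond the scatter, and the one limit leaves the size of the first open. No step beyond the scatter is therefore expected in this assay, in either direction.

For compound 4 the expected value is 75000 nM, with a range from 30000 nM to 160000 nM. The estimate for compound 4 means a step of a 1.0-fold lower number from compound 3 to compound 4 (0.02 log units; within the scatter).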

Compound 4, half-maximal inhibitory concentration: 79400 nM
For compound 4 the middle estimate is 1.1-fold (0.02 log units) below the measured one, and the stated range covers the measured number.
By their numbers in this assay, from the lowest: compounds 2, 3 and 4 (each within the scatter of the next). At a limit, above all of these: compound 1.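

In this assay, methoxy in place of bromo on this aromatic carbon, meta to a large group, gives a 1.0-fold higher number from compound 3 to compound 4 (0.00 log units; within the scatter), so the hydrogen-bond acceptor that methoxy adds does not separate the two compounds beyond the scatter. The comparison with the benzyl compound reads the same for 3-methoxyphenyl as it did for 3-bromophenyl, with a 1.5-fold higher number from compound 2 to compound 4 (0.17 log units; within the scatter) also staying within the scatter. Methoxy in place of methyl gives an at least 1.2-fold lower number from compound 1 to compound 4 (0.10 log units; that floor lies within the scatter), and since compound 1 stands at a limit of the assay, this step has only a floor: the limit of > 100000 nM in this assay, at which 1 of the 4 values shown sits.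

From the compounds shown here alone, whether any group on this aromatic carbon can move the number beyond the scatter remains open. An amine or a carboxylic acid here would test this with a different kind of substituent, and a longer chain in place of benzyl would extend the comparison on the amide-type nitrogen.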